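Sulfoxide series: trifluoromethyl entering the benzyl ring

The compounds below may be only part of what the source reports. "The series", "measured", "known", "first", "only" and "open" are said of these compounds alone.

Measured in a functional assay on BV-2 cells (Mus musculus) for inhibition, read by Griess assay, with stated times of 3 h and 24 h; on this read-out lower numbers stand for stronger inhibition and higher numbers for weaker inhibition:
compound 1 `O=S(=O)(/C=C/c1ccc(O)c(O)c1)Cc1ccc(C(F)(F)F)cc1` gives 15900 nM
compound 2 `[O-][S+](/C=C/c1ccc(O)c(O)c1)Cc1ccccc1` gives 50300 nM
compound 3 `[O-][S+](/C=C/c1ccc(O)c(O)c1)CCc1ccccc1` gives 42600 nM

Compound 2 holds the highest of the three numbers in this assay. Compound 3 lies closest, its number lower by an amount within the scatter, so no order between compound 2 and compound 3 can be stated. Compound 1 stands furthest away, with a number lower by an amount beyond the scatter; compound 1 differs from compound 2 in more than one place, so that gap is not assigned to any single change.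

Compound 4 `[O-][S+](/C=C/c1ccc(O)c(O)c1)Cc1ccc(C(F)(F)F)cc1` is not yet measured. It differs from compound 2 in one place: trifluoromethyl in place of hydrogen on an aromatic carbon. For the measured compounds named here, no pair of measured compounds shows this change on its own, so the size of the step is unknown. Compound 1 carries the same trifluoromethyl group and gives 15900 nM, the lowest number of the three, but compound 1 also differs elsewhere, so that comparison is indirect. A small move toward a lower number is expected, at most just beyond the scatter. The expected step is a 1.8-fold lower number from compound 2 to compound 4 (0.25 log units; within the scatter). Compound 4 is estimated at 28000 nM, within 12000 nM to 60000 nM.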

Compound 4, half-maximal inhibitory concentration: 15500 nM
Compound 4: middle estimate off by 1.8-fold (0.26 log units), on the high side, and the stated range covers the measured number.
By their numbers in this assay, from the lowest: compounds 4 and 1 (each within the scatter of the next); then compounds 3 and 2 (each within the scatter of the next).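

In this assay, trifluoromethyl in place of hydrogen on an aromatic carbon, para to a large group, gives a 3.2-fold lower number from compound 2 to compound 4 (0.51 log units; beyond the scatter). For the compounds shown here, this is a modest step, but it is the first single change that can be read on its own, and it lies beyond the scatter. Compound 4, at 15500 nM, falls within the scatter of compound 1, at 15900 nM, so no order can be stated between them. No measurement on hand accounts for the step.

Going by these compounds, whether a chlorine, a methoxy group or an amine at this same place would give a comparable step remains open. Also open, on these data alone, is whether trifluoromethyl would carry over to the ring of compound 3, with its longer chain.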